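The compounds below may be only part of what the source reports. "The series", "measured", "known", "first", "only" and "open" are said of these compounds alone.

Of the compounds shown here, three built on a shared core have been tested in a functional assay on 1321-N1 cells for agonist activity at Free fatty acid receptor 1 (Homo sapiens), read by calcium flux; a higher number here means a larger maximal response, a lower number a smaller maximal response. Compound 1 `O=C(O)CCc1ccc(OCc2cccc(-c3ccccc3)c2)cc1` gives 105% there. Compound 2 `O=C(O)CCc1ccc(NCc2cccc(-c3ccccc3)c2)cc1` has a core that differs from that of compound 1 in a way that is not broken down here; in this assay compound 2 gives 101%, and these two values lie within the scatter of each other. Compound 3 `Cc1ccc(-c2cccc(COc3ccc(CCC(=O)O)cc3)c2)cc1` gives 86% in this assay. Compound 3 arises from compound 1 by methyl in place of hydrogen on an aromatic carbon, and that brought a number 19 percentage points lower from compound 1 to compound 3 (beyond the scatter).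

Compound 4 `Cc1ccc(-c2cccc(CNc3ccc(CCC(=O)O)cc3)c2)cc1` has not yet been measured. It arises from compound 2 by methyl in place of hydrogen on an aromatic carbon, the same change as from compound 1 to compound 3, made at the same place. Because the earlier step of a number 19 percentage points lower from compound 1 to compound 3 (beyond the scatter) was modest but beyond the scatter, and because compound 2 starts from 101%, a similar drop is expected here, namely a number 15 percentage points lower from compound 2 to compound 4 (beyond the scatter). This rests on a single earlier example, so the expectation is tentative. Compound 4 is therefore estimated to reach 86% in this assay, with a likely range from 70% to 100%.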

Compound 4, largest response reached (reported as efficacy), in percent of the reference or control that the assay uses: 92%
Compound 4: middle estimate off by 6 percentage points, on the low side; measured number inside the range.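

Read in this assay, the change from phenyl to 4-methylphenyl on the core of compound 2 gives a number 9 percentage points lower from compound 2 to compound 4 (within the scatter). Set beside the same change on the core of compound 1, the two steps cannot be told apart: the same change on two cores in this assay, a number 19 percentage points lower (beyond the scatter) from compound 1 to compound 3 and a number 9 percentage points lower (within the scatter) from compound 2 to compound 4, 10 percentage points apart, within the scatter of two such steps. Going by these compounds alone, the change therefore carries from one core to the other with no detectable difference in size, but this rests on only two pairs, and only the step on the core of compound 1 lies beyond the scatter, so it does not show that the methyl lowers the maximal response on every core or that the two steps are truly equal.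

The compounds shown leave open whether a larger or different group at this place, such as ethyl, methoxy or trifluoromethyl, would behave as the methyl does. They also leave open what a methyl would do elsewhere on that ring, and whether the pattern would hold on a third core.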